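This account rests on a few compounds, and the source may have more. Where it says the series, first, only, none or still open, it means among the compounds named here.

Three compounds share one core: a saturated chain carbon that carries an oxygen on an unsaturated carbon, a triple-bonded carbon and one variable side group. In a functional assay on HBL-100 cells (Homo sapiens) for antiproliferative activity, read by sulforhodamine B assay, with a stated time of 48 h (a higher number here means a weaker inhibitor of growth, a lower number a stronger inhibitor of growth), compound 1 `COC(=O)C#CC(C[C@@H](C)CCC=C(C)C)O/C=C/C(=O)OC` gives 3100 nM. In this assay compound 2 `CCCCCC(C#CC(=O)OC)O/C=C/C(=O)OC` gives 1900 nM, and compound 3 `CCCCCCCCCCC(C#CC(=O)OC)O/C=C/C(=O)OC` gives 2200 nM. Among the compounds with values here, compound 2 has the lowest of the three numbers, yet the step of a 1.2-fold higher number from compound 2 to compound 3 (0.06 log units; within the scatter) is within the scatter, and the values of compound 2 and compound 1 also lie within the scatter of each other, so no compound can be set apart as the stronger or weaker inhibitor of growth.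

Compound 4 `COC(=O)C#CC(O/C=C/C(=O)OC)C(C)(C)C` has not been measured. It differs from compound 2 in one place: tert-butyl in place of pentyl on a saturated chain carbon bound to an oxygen on an unsaturated carbon and a triple-bonded carbon. Within the data shown here, the only measured step that bears on a change of the side group at this carbon is a 1.2-fold higher number from compound 2 to compound 3 (0.06 log units; within the scatter), where a much longer chain changed the number by an amount within the scatter. A shorter, branched side group is therefore expected to leave the number within the scatter as well, with no direction favoured.

Compound 4 is expected to give about 2000 nM, with a range from 1000 nM to 4200 nM. The step this estimate implies, a 1.1-fold higher number from compound 2 to compound 4 (0.02 log units; within the scatter), is expected to lie within the scatter.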

Compound 4, concentration for 50% growth inhibition: 1800 nM
Compound 4: middle estimate off by 1.1-fold (0.05 log units), on the high side; the range from low to high includes it.
By their numbers in this assay, from the lowest: compounds 4, 2, 3 and 1 (each within the scatter of the next).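

In this assay the swap of pentyl for tert-butyl on the saturated chain carbon gives a 1.1-fold lower number from compound 2 to compound 4 (0.02 log units; within the scatter) and so leaves the number effectively unchanged. Within the data shown here, until now the only single change at this position was the lengthening of a straight chain, a 1.2-fold higher number from compound 2 to compound 3 (0.06 log units; within the scatter), and that step said nothing about a shorter or branched side group. Both a longer straight chain and a compact branched group are now seen to be accepted at this carbon with no change beyond the scatter, although the data shown offer no explanation for this tolerance.

All the side groups shown at this carbon are built from carbon and hydrogen alone, so it remains open whether a phenyl ring, an amine or a carboxylic acid in that place would move the number beyond the scatter. The rest of the shared core is the same in all four compounds, which leaves open what replacing a methyl ester with an amide, or altering the triple-bonded carbon, would do to growth inhibition.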